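The source may hold more compounds than are shown below. What is called first, only, known or untested is meant among the compounds shown, and "the series" means these compounds.

In a functional assay on FM3A cells (Mus musculus) for cytotoxicity (on this read-out lower numbers stand for an effect already at smaller amounts and higher numbers for an effect only at larger amounts of compound), compound 1 (`C=C(C)COOC1(OOC)CCCCCCCCCCC1`) gives 17000 nM while compound 2 (`C=CCCOOC1(OOC)CCCCCCCCCCC1`) gives 6000 nM and compound 3 (`COOC1(OOCCC(=O)O)CCCCCCCCCCC1`) gives 450 nM as the lowest of the three numbers. Compound 4 (`COOC1(OC)CCCCCCCCCCC1`) is still unmeasured. The change from compound 3 is methyl in place of 2-carboxyethoxy on an oxygen on a saturated carbon. Two large steps bear on it: a 13-fold lower number from compound 2 to compound 3 (1.12 log units; beyond the scatter) and a 38-fold lower number from compound 1 to compound 3 (1.58 log units; beyond the scatter) both end at the carboxy compound. The step of a 2.8-fold lower number from compound 1 to compound 2 (0.45 log units; beyond the scatter) is only modest. Within the data shown here, no measured step replaces the whole 2-carboxyethoxy by methyl, so the transfer is loose. Losing the carboxy is expected to run those two large steps backwards, giving a large step to a higher number in this assay here. The estimated step is an 18-fold higher number from compound 3 to compound 4 (1.25 log units; beyond the scatter) on that reading. Compound 4 is expected at 8000 nM within an estimated range of 2000 nM to 30000 nM in this assay.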

Compound 4, half-maximal effective concentration: 19000 nM
Compound 4: middle estimate off by 2.4-fold (0.38 log units), on the low side, and the stated range covers the measured number.
By their numbers in this assay, from the lowest: compound 3; then compound 2; then compounds 1 and 4 (each within the scatter of the next).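

In this assay the change to methyl on this oxygen gives a 42-fold higher number from compound 3 to compound 4 (1.63 log units; beyond the scatter) and removes the low number of compound 3 entirely. Against (but-3-en-1-yl)oxy the same methyl gives only a 3.2-fold higher number from compound 2 to compound 4 (0.50 log units; beyond the scatter) and against (2-methylprop-2-en-1-yl)oxy it gives a 1.1-fold higher number from compound 1 to compound 4 (0.05 log units; within the scatter) with no order between those two compounds. At this position the low number therefore goes with 2-carboxyethoxy alone among the groups shown.

Open, as far as these compounds go, is whether an amide or an amine at the end of that chain, or a carboxylic acid on a longer chain, would keep the low number. Nothing on hand gives a reason for the shift.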